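The source may hold more compounds than are shown below. What is called first, only, known or untested is meant among the compounds shown, and "the series" means these compounds.

Measured so far:
compound 1, `CCCc1nc(-c2ccccc2)c(CNCCN2CCN(c3ccccc3F)CC2)o1` — 46.5%
compound 2, `CCCc1nc(-c2ccccc2)c(CNCCN2CCN(c3cccc(OC)c3)CC2)o1` — 40.2%

In an assay on HEK293 cells for inhibition of Voltage-dependent T-type calcium channel subunit alpha-1G (Homo sapiens), read by fluorescence, tested at 10 uM (on this read-out higher numbers stand for more inhibition at the one concentration tested (going by the name of the read-out) and lower numbers for less inhibition), compound 2 gives 40.2%, the smaller of the two numbers, which carries no weight on its own, since a number 6.3 percentage points lower from compound 1 to compound 2 (within the scatter). Compound 1 sits alongside it with 46.5%.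

Compound 3 is `CCCc1nc(-c2ccccc2)c(CNCCN2CCN(c3ccccc3C(F)(F)F)CC2)o1`. It differs from compound 2 in one place: 2-(trifluoromethyl)phenyl in place of 3-methoxyphenyl on an amine nitrogen in a ring. Among the measured compounds shown here, the only measured step that touches the aryl group on the ring nitrogen is a number 6.3 percentage points lower from compound 1 to compound 2 (within the scatter), and that exchange moved the number no further than repeated measurements would. Nothing in the two measured compounds points to a shift beyond the scatter when the aryl group is exchanged again, so the expectation is a step of a number 4.8 percentage points higher from compound 2 to compound 3 (within the scatter), essentially flat. Compound 3 is therefore expected to come out near 45%, with a range from 25% to 65%.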

Compound 3, a percentage reported as inhibition, at one concentration (the size of the read-out at that concentration, not a potency): 54.6%
The estimate for compound 3 lay 9.6 percentage points below the measured number; the range from low to high includes it.
By their numbers in this assay, from the lowest: compounds 2, 1 and 3 (each within the scatter of the next, the first and the last beyond it).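

In this assay, the aryl group on the ring nitrogen now yields a step that clears the scatter, a number 14.4 percentage points higher from compound 2 to compound 3 (beyond the scatter), although this exchange alters both the substituent and where it stands on the phenyl ring. Trifluoromethyl in place of fluoro on an aromatic carbon gives only a number 8.1 percentage points higher from compound 1 to compound 3 (within the scatter), so this change is not resolved from repeated-measurement noise, and the contrast at this position rests on compound 2 and compound 3 alone. No measurement bearing on the origin of either step is available.

Going by these compounds, it remains open whether the substituent or its placement accounts for the step between compound 2 and compound 3. On these data alone, the response of this position to an unsubstituted phenyl, a pyridine ring or a nitrile on the phenyl ring also remains open.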